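A few compounds are considered here, and "the series" means these few. Any claim that something is new, unique, unknown or untested is made for them only; others in the source may bear on it.

Compound 1 `C[Se]/C(=N\C(=O)c1ccco1)NC(=O)c1ccco1` gives 8660 nM in a functional assay on HepG2 cells (Homo sapiens) for cytotoxicity, read by MTT assay, with a stated time of 72 h; on this read-out higher numbers stand for weaker inhibition of growth and lower numbers for stronger inhibition of growth. Compound 2 `C[Se]/C(=N\C(=O)c1cnc2ccccc2c1)NC(=O)c1cnc2ccccc2c1` gives 23700 nM in this assay. For compound 3 `CS/C(=N\C(=O)c1cnc2ccccc2c1)NC(=O)c1cnc2ccccc2c1` this assay reports only a limit, > 100000 nM. Compound 3 therefore stands at the limit of > 100000 nM in this assay, at which 1 of the 3 values shown sits, with no number of its own.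

Compound 4 `O=C(/N=C(/NC(=O)c1cnc2ccccc2c1)[Se]Cc1ccccc1)c1cnc2ccccc2c1` differs from compound 3 by a group of 8 heavy atoms (7 carbon, 1 selenium; one six-membered aromatic ring of carbon only) in place of a group of 2 heavy atoms (1 carbon, 1 sulfur; no ring), on a carbon with a double bond to nitrogen. For the measured compounds named here, the only measured step that touches this position is an at least 4.2-fold higher number from compound 2 to compound 3 (0.62 log units; beyond the scatter), the exchange of selenium for sulfur; compound 4 reverses that exchange and at the same time carries a benzyl where compound 3 carries a methyl, a part of the change for which no measured pair exists here. A fall in the number back toward the range of compound 2 is expected. Compound 4 is expected at about 20000 nM, within 6000 nM to 70000 nM. The expected step is an at least 5.0-fold lower number from compound 3 to compound 4 (0.69 log units; beyond the scatter).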

Compound 4, concentration for total growth inhibition: 48900 nM
The estimate for compound 4 lay 2.4-fold (0.39 log units) below the measured number; the range from low to high includes it.
By their numbers in this assay, from the lowest: compound 1; then compound 2; then compound 4. At a limit, above all of these: compound 3.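

Phenyl in place of hydrogen on a saturated chain carbon bound to a selenium atom gives a 2.1-fold higher number from compound 2 to compound 4 (0.31 log units; beyond the scatter), so the position responds to a change in the group on selenium and not only to the exchange of selenium for sulfur. The benzyl selenium group still gives an at least 2.0-fold lower number from compound 3 to compound 4 (0.31 log units; beyond the scatter). Compound 3 stands only at a limit, not at a number: the limit of > 100000 nM in this assay, at which 1 of the 4 values shown sits.

Open, going by these compounds, is whether a longer chain or a terminal amine on selenium would follow the same direction. Also open, on these data alone, is whether phenyl on the core of compound 1 would give a comparable step.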